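The source may hold more compounds than are shown below. What is called first, only, known or untested is meant among the compounds shown, and "the series" means these compounds.

Working notes on the series. Compound 1 `C=C1C(=O)O[C@@H]2CC(C)=C([C@@H](C)CCCOC(C)=O)[C@H](OC(C)=O)[C@H]12` carries acetate groups on both oxygens of the shared core; in a functional assay on HL-60 cells (Homo sapiens) for activation, read by flow cytometry, with a stated time of 24 h, tested at 25 uM (a lower number here means a weaker effect, a higher number a stronger effect of the compound at the concentration tested), compound 1 gives 21.1%. Among the compounds with values here, compound 2 `C=C1C(=O)O[C@@H]2CC(C)=C([C@@H](C)CCCO)[C@H](O)[C@H]12` has both oxygens as free hydroxyls, and in this assay compound 2 gives 5.24%, the lowest of the three numbers so far. Compound 1 stands higher than compound 2 by a gap beyond the scatter, and compound 3 `C=C1C(=O)O[C@H]2/C=C(\C)CC/C=C(\C)C[C@H](O)[C@@H]12`, which in this assay gives 77.6%, stands furthest above compound 2, also beyond the scatter. Within the data shown here, no pair of measured compounds differs in one place only, so the numbers can be compared but no single step can be read from them.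

Compound 4 `C=C1C(=O)O[C@@H]2CC(C)=C([C@@H](C)CCCO)[C@H](OC(=O)C(C)CC)[C@H]12` is not yet measured. It differs from compound 2 by (sec-butyl)carbonyl in place of hydrogen on an oxygen on a saturated carbon. The other hydroxyl of compound 2 is unchanged. Among the measured compounds shown here, the only lead on direction is that compound 1, the one measured compound with esters in place of the hydroxyls, gives 21.1%, while compound 2 gives 5.24%. On that basis a step upward in this assay is expected, of moderate size, estimated as a number 14.8 percentage points higher from compound 2 to compound 4 (beyond the scatter). Compound 4 is therefore expected to give about 20% in this assay, with a range from 5% to 45%.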

Compound 4, a percentage reported as activity, at one concentration (the size of the read-out at that concentration, not a potency): 10.5%
Compound 4: middle estimate off by 9.5 percentage points, on the high side; the measured number falls inside the stated range.
By their numbers in this assay, from the lowest: compounds 2 and 4 (each within the scatter of the next); then compound 1; then compound 3.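

In this assay, within the data shown here, (sec-butyl)carbonyl in place of hydrogen on an oxygen on a saturated carbon gives a number 5.3 percentage points higher from compound 2 to compound 4 (within the scatter), the first step that can be read at a single place. At the concentration tested, then, the change from hydroxy to ((sec-butyl)carbonyl)oxy does not separate compound 4 from compound 2, with the other hydroxyl left free in both. The compounds shown offer no measurement that bears on why this step stays within the scatter.

From the compounds shown here alone, it remains open whether an ester on the other hydroxyl alone, or on both oxygens with the (sec-butyl)carbonyl group, would give a step beyond the scatter from compound 2, since compound 1 differs from compound 2 in two places and cannot settle how its two esters contribute. Also open, going by these compounds, is whether a different group on this same oxygen, such as benzoyl, a longer acyl chain or an acyl group carrying an amine, would read differently from the (sec-butyl)carbonyl of compound 4.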